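A Double-Bond Isomer of Compound 2

The compounds below may be only part of what the source reports. "The series", "measured", "known", "first", "only" and "open" are said of these compounds alone.

Compound 1 `C/C(=C\C(=O)N1CCC(Cn2c(C)nc3cnccc32)CC1)c1ccc(N)cc1` gives 0.17 mg/kg
Compound 2 `Cc1nc2cnccc2n1CC1CCN(C(=O)/C=C(/c2ccccc2)c2ccc(N)cc2)CC1` gives 0.029 mg/kg

The two compounds were tested in a functional assay on the whole organism (arterial blood) with Rattus norvegicus as the target; a lower number here means that less compound is needed, a higher number that more compound is needed for the effect. There, compound 2 gives 0.029 mg/kg, the lower of the two numbers, and the gap to compound 1, at 0.17 mg/kg, lies beyond the usual scatter. Compound 2 therefore marks the better end of this small set, though two values offer only a narrow view.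

The next compound to be measured is compound 3 `Cc1nc2cnccc2n1CC1CCN(C(=O)/C=C(\c2ccccc2)c2ccc(N)cc2)CC1`. It keeps everything found in compound 2 and changes only the geometry: the two compounds have the same atoms and bonds and differ only in configuration as drawn: 1 of 1 stereo elements differ; a double bond is drawn Z in compound 2 and E in compound 3. Nothing leaves and nothing enters, and a double bond drawn Z in compound 2 is drawn E in compound 3.

Going by the values given here, no pair of double-bond isomers has yet been measured, so the data give no direct guide to the size or direction of this step. A moderate move towards a higher number seems the likeliest outcome, since compound 2 already sits at the low end of the numbers seen so far, although a change within the scatter remains possible. The expected step is a 2.1-fold higher number from compound 2 to compound 3 (0.32 log units; beyond the scatter). For compound 3 the estimated value in this assay is 0.06 mg/kg, with an expected range from 0.012 mg/kg to 0.3 mg/kg.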

Compound 3, dose for 50% inhibition: 0.01 mg/kg
For compound 3 the middle estimate is 6.0-fold (0.78 log units) above the measured one, outside the stated range (below it).
By their numbers in this assay, from the lowest: compound 3; then compound 2; then compound 1.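

In this assay, the change of the double bond from Z to E as drawn brings a 2.9-fold lower number from compound 2 to compound 3 (0.46 log units; beyond the scatter), the first measured sign that geometry alone at this double bond can move the number beyond the scatter, and here the move favours the E form as drawn. The step can be assigned to that configuration and to nothing else, because no atom or bond changes between the two compounds: the fact that compounds 2 and 3 differ only in the configuration as drawn Phenyl in place of methyl on a double-bonded chain carbon bound to an aromatic carbon and a double-bonded chain carbon gives a 17-fold lower number from compound 1 to compound 3 (1.23 log units; beyond the scatter), a larger step that leaves compound 3 with the lowest number of the three.

The compounds shown do not tell whether the same preference for one geometry would hold with a smaller group at this carbon, such as the methyl of compound 1, or with a longer chain or a cyclohexyl ring in place of the phenyl. From the compounds shown here alone, it also remains open how much the amino group on the aromatic ring contributes, and whether a hydroxyl group or a carboxylic acid there would keep the low numbers seen for compound 3.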